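A few compounds are considered here, and "the series" means these few. Any claim that something is new, unique, unknown or untested is made for them only; others in the source may bear on it.

In an ADME assay on J774.A1 cells (Mus musculus) for cytotoxicity, read by MTT assay, with a stated time of 72 h (on this read-out higher numbers stand for lower toxicity in this test and lower numbers for higher toxicity in this test), three compounds have been measured so far:

Compound 1 `Cc1ccc(-c2ccc(C3(C)CC(S(=O)(=O)c4ccc(F)cc4)=C(c4ccc(/C(N)=N\O)cc4)O3)cc2)cc1` gives 7910 nM.
Compound 2 `CCC1(c2ccccc2OC)CC(S(=O)(=O)c2ccc(F)cc2)=C(c2ccc(/C(N)=N\O)cc2)O1` gives 9880 nM.
Compound 3 `CC1(Cc2ccccc2)CC(S(=O)(=O)c2ccccc2F)=C(c2ccc(/C(N)=N\O)cc2)O1` gives 29100 nM.

Compound 1 has the lowest of these three numbers. Its number and that of compound 2 lie within the usual scatter of such measurements, so no order between them can be read. Compound 3 stands beyond the scatter, with a clearly higher number than compound 1.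

Compound 4 `CC1(c2ccc(Br)cc2)CC(S(=O)(=O)c2ccc(F)cc2)=C(c2ccc(/C(N)=N\O)cc2)O1` has not yet been measured. It differs from compound 1 in one place: bromo in place of 4-methylphenyl on an aromatic carbon. Within the data shown here, no measured pair shows a change of this kind, so its effect is unknown. Since the three numbers span only a modest range, the expected step is small, within the scatter or barely beyond it, in either direction: a 1.3-fold higher number from compound 1 to compound 4 (0.10 log units; within the scatter). Compound 4 is therefore expected to give about 10000 nM, with a likely range from 4000 nM to 25000 nM.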

Compound 4, half-maximal cytotoxic concentration: 10500 nM
Beside the measured number, compound 4's estimate is 1.1-fold (0.02 log units) below it, and the stated range covers the measured number.
By their numbers in this assay, from the lowest: compounds 1, 2 and 4 (each within the scatter of the next); then compound 3.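

Replacing 4-methylphenyl with bromo on this aromatic carbon, para to a large group, removes a whole aromatic ring, yet in this assay the outcome is only a 1.3-fold higher number from compound 1 to compound 4 (0.12 log units; within the scatter). For this pair, then, the read-out does not separate the large group from the single atom. No available measurement offers an explanation for this result.

From the compounds shown here alone, whether an amine or a carboxylic acid at this place would also stay within the scatter remains open. So does the outcome with a longer chain there.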